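A Difluorophenyl Replaces Methoxyphenyl on the Carbonyl

This account rests on a few compounds, and the source may have more. Where it says the series, first, only, none or still open, it means among the compounds named here.

Compound 1 `COc1ccc(-c2cc(/C=C/C(=O)c3cc(OC)c(OC)c(OC)c3)[nH]n2)cc1OC`: 97%
Compound 2 `COc1ccc(C(=O)/C=C/c2cc(-c3cc(OC)c(OC)c(OC)c3)n[nH]2)cc1`: 102%

In a functional assay on NCI/ADR-RES cells (Homo sapiens) for cytotoxicity, read by sulforhodamine B assay, with a stated time of 48 h, tested at 0.01 uM (a higher number here means a weaker effect of the compound at the concentration tested, a lower number a stronger effect), compound 2 gives 102%, the higher of the two numbers, yet compound 1 with 97% sits within the usual scatter of it, so neither can be called stronger; at this concentration both show essentially no effect.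

Compound 3 `COc1cc(-c2cc(/C=C/C(=O)c3ccc(F)c(F)c3)[nH]n2)cc(OC)c1OC` differs from compound 2 in one place: 3,4-difluorophenyl in place of 4-methoxyphenyl on a carbonyl carbon. For the measured compounds named here, no measured pair shows what such a change does here. Since both measured values sit near no effect, the step of a number 4 percentage points lower from compound 2 to compound 3 (within the scatter) is expected to be none beyond the scatter. Compound 3 is therefore estimated at 98%, with a range from 85% to 110%.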

Compound 3, a percentage reported as activity, at one concentration (the size of the read-out at that concentration, not a potency): 100%
Estimate against measurement, compound 3: 2 percentage points below; the measured number falls inside the stated range.
By their numbers in this assay, from the lowest: compounds 1, 3 and 2 (each within the scatter of the next).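

The first direct test of this position, in this assay, is the exchange of 4-methoxyphenyl for 3,4-difluorophenyl on a carbonyl carbon, which gives a number 2 percentage points lower from compound 2 to compound 3 (within the scatter) and so no change that can be told from the scatter. At this single concentration, this exchange of one aromatic ring for another therefore leaves the read-out near no effect. No available evidence explains this result. As far as these compounds go, whether an amine or a carboxylic acid on this carbonyl carbon would move the number remains open. So does how compound 3 behaves at higher concentrations.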